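The source may hold more compounds than are shown below. What is called first, only, known or untested is meant among the compounds shown, and "the series" means these compounds.

Measured so far in a functional assay on SF-295 cells (Homo sapiens) for inhibition, read by sulforhodamine B assay, with a stated time of 48 h; on this read-out higher numbers stand for weaker inhibition of growth and lower numbers for stronger inhibition of growth:
compound 1 `COc1ccc(-c2[nH]c3ccccc3c2/C=C(\C#N)S(=O)(=O)c2ccccc2)cc1` — 500 nM
compound 2 `CCOC(=O)C(=Cc1c(-c2ccccc2)[nH]c2ccccc12)C(=O)OCC` — 7600 nM

Two compounds carry numbers in this assay. Compound 1 gives 500 nM, the lower of the two; compound 2 gives 7600 nM, a higher number that lies beyond the scatter of repeated measurements. The two differ in more than one place, so nothing can be said about which part of the change between them is responsible, only what the two values show.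

Compound 3 `COc1ccc(-c2[nH]c3ccc(OC)cc3c2/C=C(\C#N)S(=O)(=O)c2ccccc2)cc1` is the next compound in the series. It differs from compound 1 in one place: methoxy in place of hydrogen on an aromatic carbon of the core of compound 1. Among the compounds with values here, no measured pair shows a change of this kind, so no step of this size can be read from the data. The expectation for compound 3 rests on the value of compound 1 alone. The step of a 1.3-fold lower number from compound 1 to compound 3 (0.10 log units; within the scatter) is expected to be small, not beyond the scatter in this assay. Compound 3 is expected to give about 400 nM, with a range from 100 nM to 1600 nM.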

Compound 3, concentration for 50% growth inhibition: 760 nM
For compound 3 the middle estimate is 1.9-fold (0.28 log units) below the measured one, within the range that was stated.
By their numbers in this assay, from the lowest: compounds 1 and 3 (each within the scatter of the next); then compound 2.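

In this assay the series now has its first step with a single change (a 1.5-fold higher number from compound 1 to compound 3 (0.18 log units; within the scatter)), with methoxy in place of hydrogen on an aromatic carbon of the shared core. This carbon, on the six-membered aromatic ring of carbon only, can carry methoxy, with its one hydrogen-bond acceptor, and compound 3 remains within the scatter of compound 1, so the substitution leaves no readable mark on growth inhibition in this read-out. No measurement at hand accounts for this outcome.

Open, on these data alone, is whether the same holds for other groups on this carbon, such as a longer alkoxy chain, an amine or a carboxylic acid, and whether methoxy on the other aromatic carbons of the shared core would behave as it does here. Within the data shown here, also open is which part of the structure separates compound 2 from compound 1, as those two still differ in more than one place and no single-change step links them.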